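Moving the chlorine on the benzyl ring of a kinase inhibitor

A few compounds are considered here, and "the series" means these few. Any claim that something is new, unique, unknown or untested is made for them only; others in the source may bear on it.

Compound 1 `Cc1cc(Nc2nc(NCc3ccccc3)nc3[nH]ncc23)n[nH]1` gives 1960 nM in an assay on isolated protein for inhibition of serine/threonine-protein kinase PAK 4 (Homo sapiens), read by HTRF, with a stated time of 60 min; on this read-out lower numbers stand for stronger inhibition and higher numbers for weaker inhibition. Compound 2 `Cc1cc(Nc2nc(NCc3ccccc3F)nc3[nH]ncc23)n[nH]1` gives 389 nM, and compound 3 `Cc1cc(Nc2nc(NCc3ccccc3Cl)nc3[nH]ncc23)n[nH]1` gives 668 nM. The step of a 5.0-fold lower number from compound 1 to compound 2 (0.70 log units; beyond the scatter) and the step of a 2.9-fold lower number from compound 1 to compound 3 (0.47 log units; beyond the scatter) both exceed the scatter, whereas the step of a 1.7-fold higher number from compound 2 to compound 3 (0.23 log units; within the scatter) does not. Compound 3 thus sits second highest of the three numbers, close to compound 2 and apart from compound 1. Compound 4 `Cc1cc(Nc2nc(NCc3cccc(Cl)c3)nc3[nH]ncc23)n[nH]1` differs from compound 3 by 3-chlorophenyl in place of 2-chlorophenyl on a saturated chain carbon bound to a nitrogen on an aromatic ring. For the measured compounds named here, no measured step moves the chlorine around the ring; the only related step, a 1.7-fold higher number from compound 2 to compound 3 (0.23 log units; within the scatter), was within the scatter, so the expected step of a 1.1-fold lower number from compound 3 to compound 4 (0.05 log units; within the scatter) is small. Compound 4 is therefore estimated at 600 nM, with a range from 200 nM to 1800 nM.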

Compound 4, half-maximal inhibitory concentration: 611 nM
Estimate against measurement, compound 4: 1.0-fold (0.01 log units) below; the measured number falls inside the stated range.
By their numbers in this assay, from the lowest: compounds 2, 4 and 3 (each within the scatter of the next); then compound 1.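

Moving the chlorine from 2-chlorophenyl to 3-chlorophenyl on the saturated chain carbon gives no change that this assay can separate from scatter (a 1.1-fold lower number from compound 3 to compound 4 (0.04 log units; within the scatter)). The 3-chlorophenyl group also cannot be told apart from 2-fluorophenyl (a 1.6-fold higher number from compound 2 to compound 4 (0.20 log units; within the scatter)), yet it keeps a modest gain over the unsubstituted phenyl (a 3.2-fold lower number from compound 1 to compound 4 (0.51 log units; beyond the scatter)), so with compound 3 and compound 4 that gain holds for chloro in either named placement. No measurement here explains why the two placements read alike. Going by these compounds, whether a methoxy group or an amine in place of the chlorine, or a longer chain in place of the benzyl link, would shift the number stays open.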